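A few compounds are considered here, and "the series" means these few. Any claim that something is new, unique, unknown or untested is made for them only; others in the source may bear on it.

Measured so far:
Compound 1, `O=C(CCC1=CCN(Cc2ccc(C(F)(F)F)cc2)C1=O)NO`, gives 3070 nM.
Compound 2, `COc1ccccc1CN1CC=C(CCC(=O)NO)C1=O`, gives 6030 nM.
Compound 3, `COc1ccccc1CCCN1CC=C(CCC(=O)NO)C1=O`, gives 1500 nM.

These three numbers come from a functional assay on MDA-MB-231 cells (Homo sapiens) for antiproliferative activity; on this read-out lower numbers stand for stronger inhibition of growth and higher numbers for weaker inhibition of growth. Compound 2 has the highest number of the three. Its nearest neighbour is compound 1, whose number is within the scatter of repeated measurements of this assay, so the two cannot be told apart. Compound 3 has a number lower than that of compound 2 by a gap that lies beyond the scatter, so compound 3 does inhibit growth more strongly than compound 2.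

Compound 4, `O=C(CCC1=CCN(Cc2ccccc2)C1=O)NO`, has not yet been tested in this assay. It differs from compound 2 in one place: hydrogen in place of methoxy on an aromatic carbon. Among the measured compounds shown here, no measured pair shows this exact change, so there is no direct guide to its effect. Given that compound 1, which also carries a plain benzyl-type group with a different substituent, sits within the scatter of compound 2, the step is expected to be small and in no clear direction, roughly a 1.3-fold lower number from compound 2 to compound 4 (0.13 log units; within the scatter). Compound 4 is therefore estimated at 4500 nM, with a range from 1500 nM to 13000 nM.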

Compound 4, concentration for 50% growth inhibition: 990 nM
The estimate for compound 4 lay 4.5-fold (0.66 log units) above the measured number; the measured number lies below the stated range.
By their numbers in this assay, from the lowest: compounds 4 and 3 (each within the scatter of the next); then compounds 1 and 2 (each within the scatter of the next).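

In this assay, hydrogen in place of methoxy on an aromatic carbon gives a 6.1-fold lower number from compound 2 to compound 4 (0.78 log units; beyond the scatter), and hydrogen in place of trifluoromethyl on an aromatic carbon gives a 3.1-fold lower number from compound 1 to compound 4 (0.49 log units; beyond the scatter). The earlier numbers could not separate compound 1 from compound 2, but these two steps show that both groups, different as they are, carry a higher number than hydrogen on this six-membered aromatic ring, so among these three compounds the ring without a substituent stands lowest. Nothing available gives a reason for either step.

As far as these compounds go, whether a fluorine atom or an amine on this ring would also give a higher number than hydrogen remains open. So does whether hydrogen in place of methoxy would step the same way on the longer chain of compound 3.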